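Shortening the hydroxamate chain of a dual-warhead propargylamine

This account rests on a few compounds, and the source may have more. Where it says the series, first, only, none or still open, it means among the compounds named here.

Measured compounds:
compound 1 `C#CCN(C)CCCOc1cc(NC(=O)CCCCCCCC(=O)NO)ccc1Cl` — 20 nM
compound 2 `C#CCN(C)CCCOc1cccc(NC(=O)CCCCCCC(=O)NO)c1Cl` — 23300 nM

In an assay on GL26 cells for inhibition of Amine oxidase [flavin-containing] A (Homo sapiens), read by scintillation counting, with a stated time of 20 min (on this read-out higher numbers stand for weaker inhibition and lower numbers for stronger inhibition), compound 1 gives 20 nM and stands lowest of the two numbers measured. Compound 2, which carries a different substitution pattern on the core as well as a shorter chain, gives 23300 nM in this assay; the gap between the two values is far beyond the scatter of the measurement, but since the two structures differ in more than one place the two numbers alone do not tell how much of the gap comes from which change.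

Compound 3 `C#CCN(C)CCCOc1cc(NC(=O)CCCCCCC(=O)NO)ccc1Cl` has not yet been measured. It keeps the substitution pattern of compound 1 and differs from it only in the chain: hydroxycarbamoyl in place of (hydroxycarbamoyl)methyl on a saturated chain carbon, six bonds along the chain from a carbonyl carbon. Because compound 1 gives 20 nM and the chain is shortened by only one carbon, the step is expected to be small to moderate, towards a higher number. Compound 3 is estimated at 60 nM (range 10 nM to 600 nM), a step of a 3.0-fold higher number from compound 1 to compound 3 (0.48 log units; beyond the scatter) that is expected to stay within the general neighbourhood of compound 1.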

Compound 3, half-maximal inhibitory concentration: 3250 nM
Beside the measured number, compound 3's estimate is 54-fold (1.73 log units) below it; measured number above the stated range.
By their numbers in this assay, from the lowest: compound 1; then compound 3; then compound 2.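

In this assay, with the substitution pattern of compound 1 held fixed, hydroxycarbamoyl in place of (hydroxycarbamoyl)methyl on a saturated chain carbon, six bonds along the chain from a carbonyl carbon, gives a 160-fold higher number from compound 1 to compound 3 (2.21 log units; beyond the scatter). The earlier pair changed the chain and the substitution pattern together, whereas this step isolates the chain and shows that removing a single carbon at this position is enough, by itself, to move the number far beyond the scatter, so the read-out here is very sensitive to chain length. No measurement shown here accounts for the size of this step.

Going by these compounds, what remains open is whether the chain of compound 1 marks a best length or whether a longer chain would give a still lower number, and whether a carboxylic acid in place of the hydroxycarbamoyl end would keep any of the inhibition. It is also open how steeply chain length acts on the other substitution pattern, that of compound 2, which is shown only with the shorter chain.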